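The source may hold more compounds than are shown below. What is called first, only, known or untested is meant among the compounds shown, and "the series" means these compounds.

Compound 1, `O=S(=O)(Nc1ccc2oc(-c3ccccc3)nc2c1)c1cccc(F)c1`, gives > 63000 nM in an assay on isolated protein for inhibition of malate dehydrogenase, mitochondrial (Sus scrofa), with stated times of 45 min and 30 min (a higher number here means a weaker inhibitor, a lower number a stronger inhibitor), which is a limit of the assay rather than a number.
Compound 2, `O=S(=O)(Nc1ccc2oc(-c3ccccc3)nc2c1)c1cccc(Cl)c1`, gives > 63000 nM in this assay, again a limit.
Compound 3, `O=S(=O)(Nc1ccc2oc(-c3ccccc3)nc2c1)c1cccs1`, gives > 63000 nM in this assay, also a limit.

Compound 3 therefore stands at the upper edge of what this assay can report, and it does not stand alone there: the limit of > 63000 nM in this assay, at which 3 of the 3 values shown sit. Because of the limit of > 63000 nM in this assay, at which 3 of the 3 values shown sit, none of the steps among the three measured compounds can be sized. The step that the two limits leave unreadable from compound 1 to compound 2, the step that the two limits leave unreadable from compound 1 to compound 3 and the step that the two limits leave unreadable from compound 2 to compound 3 all remain unreadable, since both ends of each sit at the limit.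

The next compound, compound 4, `Cc1cccc(S(=O)(=O)Nc2ccc3oc(-c4ccccc4)nc3c2)c1`, differs from compound 3 by 3-methylphenyl in place of thiophen-2-yl on a sulfonyl sulfur. The measured steps that bear on this change are those into compound 3, a step that the two limits leave unreadable from compound 1 to compound 3 and a step that the two limits leave unreadable from compound 2 to compound 3, and neither gives a readable size or direction. Three aryl and heteroaryl groups on the sulfonyl sulfur have all left the shared core at the limit, so the expectation for compound 4 is that the step that the limit leaves unreadable from compound 3 to compound 4 is no more than the scatter and that compound 4 again sits at the limit. The estimate for compound 4 in this assay is 80000 nM, with a range from 30000 nM to 200000 nM.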

Compound 4, half-maximal inhibitory concentration: > 63000 nM
Compound 4 gave a limit, no number; the forecaster's own chance of this, stated with the estimate: 80%; the middle value does not contradict the limit.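

The steps from compound 1, compound 2 and compound 3 to compound 4 cannot be read, because both ends of each sit at a limit in this assay: the limit of > 63000 nM in this assay, at which 4 of the 4 values shown sit.

The compounds shown leave open whether any group on the sulfonyl sulfur, or any change to the shared core, would give a measurable value in this assay.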